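A few compounds are considered here, and "the series" means these few. Any claim that something is new, unique, unknown or untested is made for them only; others in the source may bear on it.

Working notes on the series. In a functional assay on ECa-109 cells (Homo sapiens) for inhibition, read by MTT assay, with a stated time of 72 h (on this read-out higher numbers stand for weaker inhibition and lower numbers for stronger inhibition), compound 2 `COc1ccc(Nc2nc(SCc3cn(Cc4ccccc4Cl)nn3)nc(-c3ccccc3)c2C#N)cc1` gives 7960 nM. Compound 3 `N#Cc1c(Nc2cccc(C(F)(F)F)c2)nc(SCc2cn(Cc3ccccc3Cl)nn2)nc1-c1ccccc1` gives 32000 nM in this assay, which is the highest of the two numbers shown; its nearest neighbour is compound 2, and the one measured single-point step, a 4.0-fold higher number from compound 2 to compound 3 (0.60 log units; beyond the scatter), is a modest rise on exchanging the aryl group on the ring nitrogen. Compound 1 `C#CCSc1nc(Nc2ccc(Cl)cc2)c(C#N)c(-c2ccccc2)n1` differs from compound 3 in more than one place. In this assay compound 1 gives only a limit, > 128000 nM (the limit of > 128000 nM in this assay, at which 1 of the 3 values shown sits).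

Compound 4 `N#Cc1c(Nc2ccccc2Cl)nc(SCc2cn(Cc3ccccc3Cl)nn2)nc1-c1ccccc1` is not yet measured. The change from compound 3 is 2-chlorophenyl in place of 3-(trifluoromethyl)phenyl on a nitrogen on an aromatic ring. Among the measured compounds shown here, the only measured step that bears on this position is a 4.0-fold higher number from compound 2 to compound 3 (0.60 log units; beyond the scatter), which was modest and beyond the scatter; it shows that an exchange of substituted phenyl on this nitrogen can move the number, but no measured pair carries a 2-chlorophenyl there, so the direction is open. A step of at most similar size is therefore expected, more likely downward than upward given that compound 3 already stands highest of the numbers. The expected step is a 1.6-fold lower number from compound 3 to compound 4 (0.20 log units; within the scatter). Compound 4 is estimated at 20000 nM, with a range from 5000 nM to 80000 nM in this assay.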

Compound 4, half-maximal inhibitory concentration: 28500 nM
Compound 4: middle estimate off by 1.4-fold (0.15 log units), on the low side; measured number inside the range.
By their numbers in this assay, from the lowest: compound 2; then compounds 4 and 3 (each within the scatter of the next). At a limit, above all of these: compound 1.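

In this assay, the step of a 1.1-fold lower number from compound 3 to compound 4 (0.05 log units; within the scatter) shows that 2-chlorophenyl and 3-(trifluoromethyl)phenyl on this nitrogen cannot be told apart, even though the two groups share neither substituent nor its printed ring number. The step of a 3.6-fold higher number from compound 2 to compound 4 (0.55 log units; beyond the scatter) lies beyond the scatter and runs the same way as a 4.0-fold higher number from compound 2 to compound 3 (0.60 log units; beyond the scatter), so across these three compounds, none of which goes against this, both exchanges away from 4-methoxyphenyl give a higher number, and a second group now shows that compound 2 stands apart rather than compound 3. Nothing measured here gives a cause for these steps.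

The compounds shown leave open whether the lower number of compound 2 belongs to the methoxy group itself or to the 4-substituted pattern, which an unsubstituted phenyl or a 4-chlorophenyl on the same nitrogen of the shared core would separate. They also leave open how this nitrogen tolerates a 4-substituent of another kind, such as a dimethylamino group or a carboxylic acid, or a non-aromatic group such as cyclohexyl in place of the phenyl.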